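This account rests on a few compounds, and the source may have more. Where it says the series, first, only, none or still open, it means among the compounds named here.

In an assay for inhibition of Type-2 angiotensin II receptor (Rattus norvegicus) (a higher number here means a weaker inhibitor, a lower number a stronger inhibitor), compound 1 `CCCCCN(CCCCC)C(=O)N1CCN(C(=O)N(c2ccccc2)c2ccccc2)[C@H](C(=O)O)C1` gives 1.4 nM. Compound 2 `CN(C(=O)N1CCN(C(=O)N(c2ccccc2)c2ccccc2)[C@H](C(=O)O)C1)c1ccccc1` gives 170 nM. Compound 3 `CCCCCN(CCCCC)C(=O)N1CCN(C(=O)N(c2ccccc2)c2cccc(Cl)c2)[C@H](C(=O)O)C1` gives 0.4 nM.

Among these three numbers compound 3 holds the lowest. Within the data shown here, the step from compound 1 to compound 3 was a 3.5-fold lower number from compound 1 to compound 3 (0.54 log units; beyond the scatter), and the value of compound 2 lies far above that of compound 3, with no single-point step between those two. The other measured step, from compound 1 to compound 2, was a 120-fold higher number from compound 1 to compound 2 (2.08 log units; beyond the scatter), a change at the carbonyl carbon on the far side of the core and not at the aromatic ring.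

Compound 4 `CCCCCN(CCCCC)C(=O)N1CCN(C(=O)N(c2ccccc2)c2cccc(Br)c2)[C@H](C(=O)O)C1` differs from compound 3 by bromo in place of chloro on an aromatic carbon. Among the measured compounds shown here, no measured step in this set exchanges one halogen for another; the only step touching this ring, from compound 1 to compound 3, brought in the chloro and was modest in size. Swapping that chloro for bromo is a smaller change than adding it, so compound 4 is expected to sit close to compound 3 in this assay, with no step beyond the scatter in either direction. The step from compound 3 to compound 4 is therefore estimated at no change at the digits printed from compound 3 to compound 4 (within the scatter). Compound 4 is expected to give about 0.4 nM, within a range from 0.15 nM to 1.2 nM.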

Compound 4, half-maximal inhibitory concentration: 0.6 nM
Compound 4: the middle estimate sits 1.5-fold (0.18 log units) below what was measured, and the stated range covers the measured number.
By their numbers in this assay, from the lowest: compounds 3 and 4 (each within the scatter of the next); then compound 1; then compound 2.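

In this assay, the change from 3-chlorophenyl to 3-bromophenyl gives a 1.5-fold higher number from compound 3 to compound 4 (0.18 log units; within the scatter) and so does not separate these two halogens at this place on the aromatic ring. Set against the unsubstituted ring, bromo in place of hydrogen gives a 2.3-fold lower number from compound 1 to compound 4 (0.37 log units; beyond the scatter) and so provides a second case, after the chloro of compound 3, of a halogen at this place lowering the number beyond the scatter, a pattern that rests on these two compounds alone. No measurement among the data shown bears on why the two halogens read alike.

The compounds shown leave open whether other groups at this place, such as fluoro, methyl, methoxy or a nitrile, would match the chloro and bromo or depart from them. They also leave open whether either halogen would lower the number in the same way on compound 2, which carries methyl(phenyl)amino in place of dipentylamino on the carbonyl carbon.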